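The compounds below may be only part of what the source reports. "The series", "measured", "known", "first", "only" and "open" are said of these compounds alone.

Compound 2 `COc1ccccc1COc1ccccc1OCCNCCOc1c(OC)cccc1OC` holds the lowest of the two numbers recorded in a functional assay on PC-3 cells (Homo sapiens) for cytotoxicity, read by sulforhodamine B assay (on this read-out higher numbers stand for weaker inhibition of growth and lower numbers for stronger inhibition of growth), giving 30200 nM, while compound 1 `COc1cccc(OC)c1OCCNCCOc1ccccc1OCc1ccccc1` gives 76900 nM. For the measured compounds named here, the single measured step, a 2.5-fold lower number from compound 1 to compound 2 (0.41 log units; beyond the scatter), concerns the addition of a methoxy group and does not bear directly on moving a methoxy group around a ring. Compound 3 `COc1ccc(COc2ccccc2OCCNCCOc2c(OC)cccc2OC)cc1` differs from compound 2 by 4-methoxyphenyl in place of 2-methoxyphenyl on a saturated chain carbon bound to an oxygen on an aromatic ring. Going by the values given here, with no measured step matching this change, the step from compound 2 to compound 3 is expected to be a 1.0-fold lower number from compound 2 to compound 3 (0.00 log units; within the scatter), not beyond the scatter. Compound 3 is therefore estimated at 30000 nM, with a range from 10000 nM to 90000 nM.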

Compound 3, concentration for total growth inhibition: 34700 nM
The estimate for compound 3 lay 1.2-fold (0.06 log units) below the measured number, and the stated range covers the measured number.
By their numbers in this assay, from the lowest: compounds 2 and 3 (each within the scatter of the next); then compound 1.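

In this assay, 4-methoxyphenyl in place of 2-methoxyphenyl on a saturated chain carbon bound to an oxygen on an aromatic ring gives a 1.1-fold higher number from compound 2 to compound 3 (0.06 log units; within the scatter) and so does not separate the two groups. Both still stand apart from the unsubstituted ring, with a 2.2-fold lower number from compound 1 to compound 3 (0.35 log units; beyond the scatter) in the same direction as the earlier methoxy step. No measurement on hand accounts for this. On these data alone, whether an amine or a carboxylic acid in place of the methoxy, or a longer chain at this position, would move the number remains open.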